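The source may hold more compounds than are shown below. What is called first, only, known or untested is meant among the compounds shown, and "the series" means these compounds.

Of the compounds shown here, two built on one shared core have been measured so far. Compound 1, `COc1cccc(C(=O)Nc2cc(-c3ccccc3)nn2-c2ccccc2)c1`, gives 1290 nM in an assay on HEK293 cells for displacement of a labelled ligand from metabotropic glutamate receptor 5 (Rattus norvegicus); on this read-out lower numbers stand for stronger inhibition and higher numbers for weaker inhibition. Compound 2, `O=C(Nc1cc(-c2ccccc2)nn1-c1ccccc1)c1ccc(OC(F)(F)F)cc1`, gives 265 nM in this assay, the lowest of the two numbers; the number for compound 1 sits higher by a gap beyond the usual scatter, so compound 2 is the stronger binder of this pair. The next compound, compound 3, `O=C(O)c1ccc(C(=O)Nc2cc(-c3ccccc3)nn2-c2ccccc2)cc1`, has not yet been measured. It differs from compound 2 in a single place: carboxy in place of trifluoromethoxy on an aromatic carbon. Among the compounds with values here, no measured pair shows a change of this kind, so there is no direct step to lean on, and the expectation rests on the two measured values alone. The number is expected to rise, by a step of about an 11-fold higher number from compound 2 to compound 3 (1.05 log units; beyond the scatter) in this assay. Compound 3 is therefore expected to give about 3000 nM in this assay, with a range from 800 nM to 12000 nM.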

Compound 3, inhibition constant: > 10000 nM
Compound 3: a limit, no number (the forecaster's own chance of this, stated with the estimate: 25%); at least 3.3-fold (0.52 log units) between middle value and limit.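

In this assay, compound 3 gives a limit and not a number: the limit of > 10000 nM in this assay, at which 1 of the 3 values shown sits.

The steps into compound 3 are therefore minimum sizes: carboxy in place of trifluoromethoxy on this aromatic carbon gives an at least 37-fold higher number from compound 2 to compound 3 (1.57 log units; beyond the scatter), and 4-carboxyphenyl in place of 3-methoxyphenyl gives an at least 7.7-fold higher number from compound 1 to compound 3 (0.88 log units; beyond the scatter). Within the data shown here, the earlier pair showed only that binding changes with the group on this ring, whereas this result shows that one swap at this place can take binding out of the range the assay can put a number on.

On these data alone, how far past the limit compound 3 lies remains unknown, and so does which feature of the carboxy group matters. A methyl ester, a primary amide or a hydroxy group at this same place could show whether the loss belongs to the carboxy group alone.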